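Trimming the sulfonamide of compound 1 to a methylsulfonyl

The source may hold more compounds than are shown below. What is called first, only, known or untested is meant among the compounds shown, and "the series" means these compounds.

Compound 1 `Cc1ccc(S(=O)(=O)N2CCN(C)CC2)cc1C#Cc1cc(Cl)ccc1OCC(=O)O` was tested in an assay on CHO cells for displacement of a labelled ligand from prostaglandin D2 receptor 2 (Homo sapiens), read by scintillation counting (on this read-out higher numbers stand for weaker inhibition and lower numbers for stronger inhibition), and gave 21 nM. Its companion, compound 2 `Cc1ncc(S(=O)(=O)N(C)C)cc1C#Cc1cc(Cl)ccc1OCC(=O)O`, gave 41 nM in this assay; the two numbers sit within the scatter of each other, so neither can be set ahead. Compound 3 `Cc1ccc(S(C)(=O)=O)cc1C#Cc1cc(Cl)ccc1OCC(=O)O` has not yet been measured in this assay. It differs from compound 1 in one place: methyl in place of 4-methylpiperazin-1-yl on a sulfonyl sulfur. Among the measured compounds shown here, with no measured step of this kind to lean on, the step of a 1.7-fold higher number from compound 1 to compound 3 (0.22 log units; within the scatter) is expected to be small, toward a somewhat higher number, and hardly beyond the scatter. Compound 3 is therefore estimated at 35 nM, within 12 nM to 100 nM.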

Compound 3, inhibition constant: 5 nM
Compound 3: middle estimate off by 7.0-fold (0.85 log units), on the high side; measured number outside the range, below it.
By their numbers in this assay, from the lowest: compound 3; then compounds 1 and 2 (each within the scatter of the next).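

In this assay, methyl in place of 4-methylpiperazin-1-yl on the sulfonyl sulfur gives a 4.2-fold lower number from compound 1 to compound 3 (0.62 log units; beyond the scatter), a step beyond the scatter. This place on the sulfonyl sulfur therefore does not need the six-membered ring for binding in this series, and the single carbon of methyl gives the lower number. Nothing available accounts for this step. As far as these compounds go, whether an ethyl or a cyclopropyl on the same sulfur would hold or extend this gain remains open. So does whether a plain amino group there, giving a primary sulfonamide, would match methyl.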